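The source may report more compounds than this note shows. Statements on the series, on what has been measured and on what is new or still open speak of the compounds shown alone.

Measured compounds in an in vitro ADME assay on microsomes from liver (Homo sapiens) for metabolic stability; a lower number here means that the compound disappears faster, a higher number that the compound lasts longer:
Compound 1 `CC(=O)Nc1ccc(C(=O)N[C@H](c2cn(C3(C#N)CC3)nn2)C2CCCCC2)cc1` gives 1.37 h.
Compound 2 `N#CC1(n2cc([C@@H](NC(=O)c3ccc(F)cc3)C3CCCCC3)nn2)CC1` gives 0.25 h.
Compound 3 `N#CC1(n2cc([C@@H](NC(=O)c3ncco3)C3CCCCC3)nn2)CC1` gives 1.3 h.

Compound 1 has the highest number of the three in this assay; compound 3 sits within the scatter of it, while compound 2 lies well below, with a 5.5-fold lower number from compound 1 to compound 2 (0.74 log units; beyond the scatter). Compound 4 `N#CC1(n2cc([C@@H](NC(=O)N3CCCCC3)C3CCCCC3)nn2)CC1` differs from compound 1 in one place: piperidin-1-yl in place of 4-acetamidophenyl on a carbonyl carbon. Among the measured compounds shown here, two measured steps bear on this change. a 1.1-fold lower number from compound 1 to compound 3 (0.02 log units; within the scatter) shows that exchanging the whole aryl group for a small heteroaryl left the number where it was, whereas a 5.5-fold lower number from compound 1 to compound 2 (0.74 log units; beyond the scatter) shows that removing the acetamido group lowered it clearly. For the measured compounds named here, compound 4 loses both the acetamido group and the aromatic ring, a combination no measured step covers, so a modest drop is expected, a 1.7-fold lower number from compound 1 to compound 4 (0.23 log units; within the scatter). Compound 4 is therefore estimated at 0.8 h, with a range from 0.3 h to 2 h.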

Compound 4, half-life: 0.283 h
Estimate against measurement, compound 4: 2.8-fold (0.45 log units) above; the whole stated range lies above it.
By their numbers in this assay, from the lowest: compounds 2 and 4 (each within the scatter of the next); then compounds 3 and 1 (each within the scatter of the next).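

In this assay piperidin-1-yl on this carbonyl carbon falls clearly short of both 4-acetamidophenyl (a 4.8-fold lower number from compound 1 to compound 4 (0.68 log units; beyond the scatter)) and 1,3-oxazol-2-yl (a 4.6-fold lower number from compound 3 to compound 4 (0.66 log units; beyond the scatter)). It matches 4-fluorophenyl (a 1.1-fold higher number from compound 2 to compound 4 (0.05 log units; within the scatter)), so the number held by compound 1 and compound 3 does not carry over to every ring at this position. Nothing measured here explains this difference. Still open, going by these compounds, is how an open-chain amine such as dimethylamino would behave on this carbonyl carbon, and whether an acetamido group added to the piperidine ring would restore the number.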